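Nitro to amino exchange and cytotoxicity across two cores

This account rests on a few compounds, and the source may have more. Where it says the series, first, only, none or still open, it means among the compounds named here.

The series is read in an ADME assay on BHK cells (Mesocricetus auratus) for cytotoxicity, read by MTT assay, with a stated time of 96 h; on this read-out higher numbers stand for lower toxicity in this test and lower numbers for higher toxicity in this test. Compound 1 `COc1ccc(-c2nc3cc(Cl)c(Cl)cc3[nH]2)c([N+](=O)[O-])c1` gives 80000 nM. Compound 2 `COc1ccc(-c2nc3cc(Cl)c(Cl)cc3[nH]2)c(N)c1` carries amino in place of nitro on an aromatic carbon. In this assay compound 2 reaches only the limit of the test at > 100000 nM. The step is therefore a floor: an at least 1.2-fold higher number from compound 1 to compound 2 (0.09 log units; that floor lies within the scatter), and it is bounded because the limit of > 100000 nM in this assay, at which 1 of the 3 values shown sits, is where compound 2 sits. Compound 3 `COc1ccc(-c2nc3cc(C(F)(F)F)ccc3[nH]2)c([N+](=O)[O-])c1` gives 100000 nM; this value and that of compound 1 lie within the usual scatter of each other, so nothing is said here about their order. How the core of compound 3 differs from the core of compound 1 is not broken down here.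

Compound 4 `COc1ccc(-c2nc3cc(C(F)(F)F)ccc3[nH]2)c(N)c1` is not yet measured in this assay. It stands to compound 3 as compound 2 stands to compound 1: amino in place of nitro on an aromatic carbon. The surroundings of the place are described in the same words for both pairs, so this is taken as the same change. The step expected here is a 1.3-fold higher number from compound 3 to compound 4 (0.11 log units; within the scatter), set beside the measured at least 1.2-fold higher number from compound 1 to compound 2 (0.09 log units; that floor lies within the scatter), on the reasoning that the same exchange in the core of compound 1 gave no fall in the number. Since compound 3 already sits at the edge of what this assay reports, compound 4 is expected to give 130000 nM, with an expected range from 70000 nM to 260000 nM, and a limit rather than a number is the more likely outcome.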

Compound 4, half-maximal cytotoxic concentration: >= 100000 nM
Compound 4 was reported as a limit (the forecaster's own chance of this, stated with the estimate: 65%); the middle value lies beyond the limit too.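

In this assay, amino in place of nitro on an aromatic carbon gives a number no lower from compound 3 to compound 4 (the limit leaves the size open), and the size of this step cannot be read. Set beside the same exchange on the core of compound 1, the new step shows no fall in the number on either core, but the two steps cannot be told apart: the same change on two cores in this assay, an at least 1.2-fold higher number (0.09 log units; that floor lies within the scatter) from compound 1 to compound 2 and a number no lower (the limit leaves the size open) from compound 3 to compound 4; the limit leaves it open whether they differ

So the notes can carry over only the absence of a fall across these two cores; they cannot carry over a size for the change, and they do not show that the exchange acts alike on both cores, since the readings of compound 2 and compound 4 are limits and not numbers.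

Left open is whether any other group at this place, such as a hydroxyl, an acetamide or a dimethylamino group, would bring the number in this assay down from the limit on either core. Also open, going by these compounds, is whether the exchange of nitro for amino would read the same on a core carrying a nitrile or a carboxylic acid in place of the trifluoromethyl group.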